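The source may hold more compounds than are shown below. What is called first, only, known or untested is meant among the compounds shown, and "the series" means these compounds.

In an assay on HEK293 cells for inhibition of Voltage-dependent T-type calcium channel subunit alpha-1G (Homo sapiens), read by fluorescence, tested at 10 uM (on this read-out lower numbers stand for less inhibition and higher numbers for more inhibition at the one concentration tested (going by the name of the read-out)), the measured compounds stand as follows:

compound 1 `CCCc1nc(-c2ccccc2)c(CNCCN2CCN(c3ccccc3F)CC2)o1`: 46.5%
compound 2 `CCCc1nc(-c2ccccc2)c(CNCCN2CCN(c3ccccc3C(F)(F)F)CC2)o1`: 54.6%
compound 3 `CCCc1nc(-c2ccccc2)c(CNCCN2CCN(c3ccc(OC)cc3)CC2)o1`: 51.5%

Compound 3 holds the second highest of the three numbers; its nearest neighbour is given by a number 3.1 percentage points lower from compound 2 to compound 3 (within the scatter), its furthest by a number 5 percentage points higher from compound 1 to compound 3 (within the scatter), both within the scatter. Compound 4 `CCCc1nc(-c2ccccc2)c(CNCCN2CCN(c3cccc(C)c3C)CC2)o1` differs from compound 3 by 2,3-dimethylphenyl in place of 4-methoxyphenyl on an amine nitrogen in a ring. Among the compounds with values here, the steps that bear on this are the two earlier swaps of the aryl group on the ring nitrogen, a number 5 percentage points higher from compound 1 to compound 3 (within the scatter) and a number 3.1 percentage points lower from compound 2 to compound 3 (within the scatter), neither beyond the scatter. A third such swap is therefore expected to give no step beyond the scatter in this assay, that is a number 1.5 percentage points lower from compound 3 to compound 4 (within the scatter). Compound 4 is estimated at 50%, within 35% to 65%.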

Compound 4, a percentage reported as inhibition, at one concentration (the size of the read-out at that concentration, not a potency): 66.7%
For compound 4 the middle estimate is 16.7 percentage points below the measured one, outside the stated range (above it).
By their numbers in this assay, from the lowest: compounds 1, 3 and 2 (each within the scatter of the next); then compound 4.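

In this assay the aryl group on the amine nitrogen in a ring gives its first steps beyond the scatter with 2,3-dimethylphenyl, namely a number 15.2 percentage points higher from compound 3 to compound 4 (beyond the scatter) and a number 12.1 percentage points higher from compound 2 to compound 4 (beyond the scatter) and a number 20.2 percentage points higher from compound 1 to compound 4 (beyond the scatter). Compound 4 therefore stands clear of compound 1, compound 2 and compound 3, which remain within the scatter of their neighbours, so this position does respond to the choice of aryl group. No measurement at hand accounts for the gain.

Open, going by these compounds, is whether a single methyl group, an ethyl group or a chlorine on the phenyl ring would hold this level. Also open, on these data alone, is whether a pyridine in place of the phenyl ring would do so.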